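The source may hold more compounds than are shown below. What is called first, only, known or untested is meant among the compounds shown, and "the series" means these compounds.

Compound 1 `Oc1cccc(-c2cc(-c3cccnc3)nc(-c3cccc(Cl)c3)c2)c1` gives 27.6% in an assay on isolated protein for inhibition of DNA topoisomerase 1 (Homo sapiens), with a stated time of 30 min, tested at 100 uM (a lower number here means a weaker effect, a higher number a stronger effect of the compound at the concentration tested), the second highest of three numbers measured there. Compound 2 `Oc1cccc(-c2cc(-c3cccnc3)nc(-c3ccccc3Cl)c2)c1` gives 0% in this assay, a step of a number 27.6 percentage points lower from compound 1 to compound 2 (beyond the scatter). Compound 3 `Oc1ccc(-c2cc(-c3cccnc3)nc(-c3cccc(Cl)c3)c2)cc1` gives 55.2% in this assay, a step of a number 27.6 percentage points higher from compound 1 to compound 3 (beyond the scatter). Compound 4 `Oc1cccc(-c2cc(-c3ccccc3)nc(-c3cccc(Cl)c3)c2)c1` has not yet been measured; it differs from compound 1 by phenyl in place of pyridin-3-yl on an aromatic carbon. Among the compounds with values here, neither measured step touches this group: one alters the chlorophenyl ring, the other the hydroxyphenyl ring, so no measured step bears on the change. Without such guidance, a step of a number 5.6 percentage points lower from compound 1 to compound 4 (within the scatter) within the scatter is expected. Compound 4 is therefore estimated to give 22% in this assay, with a range from 0% to 45%.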

Compound 4, a percentage reported as inhibition, at one concentration (the size of the read-out at that concentration, not a potency): 11.5%
Compound 4: middle estimate off by 10.5 percentage points, on the high side; the range from low to high includes it.
By their numbers in this assay, from the lowest: compound 2; then compound 4; then compound 1; then compound 3.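

Within the data shown here, replacing pyridin-3-yl with phenyl gives a number 16.1 percentage points lower from compound 1 to compound 4 (beyond the scatter) in this assay and shows that this position, which the earlier steps left untouched, also affects the read-out. The swap exchanges only the ring nitrogen, and with it the hydrogen-bond acceptor counted for pyridin-3-yl, for carbon. Nothing at hand explains the direction of this step.

As far as these compounds go, it remains open whether pyridin-4-yl, or a phenyl ring carrying an amine or a carboxylic acid, would give a higher number here. From the compounds shown here alone, it is also open whether the step would hold with the 4-hydroxyphenyl group of compound 3.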